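Fluorine on the Benzyl Group: Compound 3 to Compound 4

This account rests on a few compounds, and the source may have more. Where it says the series, first, only, none or still open, it means among the compounds named here.

Compound 3 `OCCNc1nc(-c2ccccc2)nc2c1nnn2Cc1ccccc1` gives 38 nM in an assay on Cerebral cortex for displacement of a labelled ligand from adenosine receptor A1 (Bos taurus) (on this read-out lower numbers stand for stronger inhibition and higher numbers for weaker inhibition), the highest of the three numbers. It lies within the scatter of compound 2 `CCCCCCNc1nc(-c2ccccc2)nc2c1nnn2Cc1ccccc1F`, which gives 25 nM. Compound 3 lies beyond the scatter from compound 1 `CCCCNc1nc(-c2ccccc2)nc2c1nnn2Cc1ccccc1F`, which gives 4.3 nM. Among the measured compounds shown here, the only measured step, a 5.8-fold higher number from compound 1 to compound 2 (0.76 log units; beyond the scatter), concerns the chain on the ring nitrogen and does not bear on the change to compound 4 `OCCNc1nc(-c2ccccc2)nc2c1nnn2Cc1ccccc1F`, which is fluoro in place of hydrogen on an aromatic carbon. For the measured compounds named here, no measured pair isolates this change; compounds 1 and 2 carry the fluorine but differ from compound 3 in the chain as well, so the direction is uncertain. The step expected here, a 1.9-fold lower number from compound 3 to compound 4 (0.28 log units; within the scatter), stays within the scatter. The estimate for compound 4 is 20 nM, with a range from 6 nM to 70 nM.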

Compound 4, inhibition constant: 54 nM
Compound 4: the middle estimate sits 2.7-fold (0.43 log units) below what was measured; the measured number falls inside the stated range.
By their numbers in this assay, from the lowest: compound 1; then compounds 2, 3 and 4 (each within the scatter of the next, the first and the last beyond it).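

In this assay fluoro in place of hydrogen, on an aromatic carbon ortho to a large group, gives a 1.4-fold higher number from compound 3 to compound 4 (0.15 log units; within the scatter) and so shows no change beyond the scatter in this one pair. With 2-fluorobenzyl held fixed, the chain shows the clearer steps: hydroxy in place of butyl gives a 2.2-fold higher number from compound 2 to compound 4 (0.33 log units; beyond the scatter) and hydroxy in place of ethyl gives a 13-fold higher number from compound 1 to compound 4 (1.10 log units; beyond the scatter) as the largest step shown here. No evidence is available to explain these results. From the compounds shown here alone, it remains open whether fluoro would read the same on the butyl chain of compound 1. Chloro or methoxy on that aromatic carbon, or an amine in place of hydroxy on the chain, also remain untested in the compounds shown.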